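Swapping the Sulfonyl Substituent in a Kinase-Directed Series

A few compounds are considered here, and "the series" means these few. Any claim that something is new, unique, unknown or untested is made for them only; others in the source may bear on it.

Three compounds that share a core and differ in the group carried on the sulfonyl sulfur, and in the substitution of the indole, have been measured in a functional assay on DU-145 cells (Homo sapiens) for inhibition, read by trypan blue exclusion, with a stated time of 72 h; on this read-out higher numbers stand for weaker inhibition and lower numbers for stronger inhibition. Compound 1, with the structure `Cn1c(=O)c(S(=O)(=O)Cc2ccc(F)cc2F)cc2cnc(Nc3ccc4[nH]ccc4c3)nc21`, gives 1000 nM in this assay. This is the highest of the three numbers, yet it sits within the usual scatter of the other two. Compound 2, `Cc1cc2cc(Nc3ncc4cc(S(=O)(=O)c5ccc(F)cc5F)c(=O)n(C)c4n3)ccc2[nH]1`, gives 750 nM in this assay, and compound 3, `CCn1c(=O)c(S(=O)(=O)c2ccc(F)cc2F)cc2cnc(Nc3ccc4[nH]ccc4c3)nc21`, gives 750 nM. No pairwise step among these three stands beyond the scatter, so nothing can be called stronger or weaker here.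

Compound 4, `Cn1c(=O)c(S(=O)(=O)c2ccc(Br)cc2)cc2cnc(Nc3ccc4[nH]ccc4c3)nc21`, has not yet been measured. It differs from compound 1 in one place: 4-bromophenyl in place of 2,4-difluorobenzyl on a sulfonyl sulfur. Going by the values given here, none of the measured pairs isolates this change, so there is no directly comparable step to lean on. With all three measured numbers lying close together, the expected step from compound 1 to compound 4 is a 1.1-fold lower number from compound 1 to compound 4 (0.05 log units; within the scatter), not beyond the scatter in either direction. Compound 4 is therefore estimated at 900 nM in this assay, with a range from 300 nM to 3000 nM.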

Compound 4, half-maximal inhibitory concentration: 5000 nM
Estimate against measurement, compound 4: 5.6-fold (0.74 log units) below; the whole stated range lies below it.
By their numbers in this assay, from the lowest: compounds 2, 3 and 1 (each within the scatter of the next); then compound 4.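

In this assay the group on the sulfonyl sulfur proves able to shift the read-out: 4-bromophenyl in place of 2,4-difluorobenzyl gives a 5.0-fold higher number from compound 1 to compound 4 (0.70 log units; beyond the scatter), which means weaker inhibition. The three earlier compounds all lie within the scatter of one another, so they gave no sign that a change here could matter this much. No available evidence explains the step.

This single swap alters two things at once, the halogen on the ring and the extra carbon that links the 2,4-difluorobenzyl ring to the sulfur, and the compounds shown do not separate them. From the compounds shown here alone, it also remains open how a 4-bromobenzyl group, an unsubstituted phenyl ring or an amine would behave on the same sulfur.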